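Notes on compound 3 and the step to compound 4

A few compounds are considered here, and "the series" means these few. Any claim that something is new, unique, unknown or untested is made for them only; others in the source may bear on it.

Three compounds have numbers in a functional assay on HEK293 cells for antagonist activity at Oxytocin receptor (Homo sapiens), read by calcium flux, with a stated time of 10 min, in the presence of a further agent that is not named here; a higher number here means a weaker inhibitor, a lower number a stronger inhibitor. Compound 1 `COCc1nnc(N2CC3CN(c4ccc(F)cc4Cl)CC32)n1-c1ccc(OC)nc1` gives 850 nM. Compound 2 `COCc1nnc(N2CC3COCC3(c3ccc(F)cc3Cl)C2)n1-c1ccc(OC)nc1` gives 2560 nM. Compound 3 `CCOCc1nnc(N2C[C@@H]3C[C@]3(c3ccc(F)cc3Cl)C2)n1-c1ccc(OC)nc1` gives 9.3 nM, the lowest of the three; compound 1 stands nearest, with a number higher by a margin beyond the scatter, and compound 2 stands furthest, also beyond the scatter. For the measured compounds named here, compounds 1 and 2 each differ from compound 3 in more than one place, so no single-point step among the measured compounds is available to anchor a prediction.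

Compound 4 `COc1ccc(-n2c(C(F)F)nnc2N2C[C@@H]3C[C@]3(c3ccc(F)cc3Cl)C2)cn1` has not yet been measured in this assay. It differs from compound 3 in one place: difluoromethyl in place of ethoxymethyl on an aromatic carbon. Going by the values given here, no measured pair in this set shows what this kind of exchange does on the shared core, so the expectation rests on compound 3 alone. A step of modest size is expected, in the direction of a somewhat higher number, though a result within the scatter of compound 3 would not be surprising. The estimate implies a 1.9-fold higher number from compound 3 to compound 4 (0.29 log units; within the scatter). Compound 4 is expected to give 18 nM in this assay, with a range from 4 nM to 80 nM.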

Compound 4, half-maximal inhibitory concentration: 52 nM
The estimate for compound 4 lay 2.9-fold (0.46 log units) below the measured number; the range from low to high includes it.
By their numbers in this assay, from the lowest: compound 3; then compound 4; then compound 1; then compound 2.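

In this assay, for the compounds shown here, placing difluoromethyl instead of ethoxymethyl on this aromatic carbon, between two ring nitrogen atoms of the five-membered ring, gives a 5.6-fold higher number from compound 3 to compound 4 (0.75 log units; beyond the scatter), the first single-place reading and one beyond the scatter. The position is therefore sensitive to its substituent, yet ethoxymethyl is not a strict requirement: compound 4, which carries a smaller group with no hydrogen-bond acceptor, still gives 52 nM. No supporting measurement is available to show which feature of the exchange accounts for the step.

Going by these compounds alone, with only two groups compared on the shared core, the contributions of chain length, the ether oxygen and the fluorine atoms cannot be separated. As far as these compounds go, a plain propyl chain would test the chain without its oxygen, trifluoromethyl would extend the fluorinated side of the comparison, and a primary amine or a carboxylic acid would show how far this position tolerates a quite different group, all of which remain open here.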